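Ester shortening in a weakly cytotoxic series

The source may hold more compounds than are shown below. What is called first, only, known or untested is meant among the compounds shown, and "the series" means these compounds.

Compound 1 `C=C1[C@H](OC(C)=O)[C@H]2[C@@H](OC(C)=O)[C@@H](C)C[C@]2(OC(C)=O)C(=O)[C@@H](C)/C=C/C(C)(C)C(=O)[C@H](OC(C)=O)[C@H]1OC(=O)C(C)C` and compound 2 `C=C1CCC(=O)C(C)(C)/C=C/[C@H](C)C(=O)[C@@]2(OC(C)=O)C[C@H](C)[C@H](O)[C@@H]2[C@H]1OC(=O)c1ccccc1` share a core and have both been tested in an ADME assay on NCI/ADR-RES cells (Homo sapiens) for cytotoxicity, read by MTT assay, with a stated time of 48 h; on this read-out lower numbers stand for stronger inhibition and higher numbers for weaker inhibition. Compound 1 reaches only the limit of the assay, > 100000 nM, which is not a number. Compound 2 gives 90900 nM. For the measured compounds named here, no step between these two is computed here; their values simply show that both sit at the weak end of the range. Where compound 1 stands is thus fixed only by the limit (the limit of > 100000 nM in this assay, at which 1 of the 2 values shown sits).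

Compound 3 `C=C1[C@H](OC(C)=O)[C@H]2[C@@H](OC(C)=O)[C@@H](C)C[C@]2(OC(C)=O)C(=O)[C@@H](C)/C=C/C(C)(C)C(=O)[C@H](OC(C)=O)[C@H]1OC(=O)CC` is not yet measured. It differs from compound 1 by hydrogen in place of methyl on a saturated chain carbon bound to a carbonyl carbon and a saturated chain carbon: isopropylcarbonyl becomes propanoyl, the (isopropylcarbonyl)oxy group becoming propanoyloxy. Going by the values given here, with no measured step to lean on, no change beyond the usual scatter is expected in this assay from this exchange of a methyl for hydrogen on a saturated chain carbon bound to a carbonyl carbon and a saturated chain carbon. Compound 3 is therefore expected to land at 120000 nM, within 50000 nM to 300000 nM, most likely reported again as a limit. The expected step that the limit leaves unreadable from compound 1 to compound 3 is none beyond the scatter.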

Compound 3, half-maximal inhibitory concentration: > 100000 nM
Compound 3: a limit, no number; the forecaster's own chance of this, stated with the estimate: 70%; the middle value lies beyond the limit too.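

In this assay compound 3 gives > 100000 nM, a limit and not a number. Compound 1 gives > 100000 nM, also a limit, so no step can be read between compound 1 and compound 3: the limit of > 100000 nM in this assay, at which 2 of the 3 values shown sit. The compounds shown leave open whether hydrogen in place of methyl on this saturated chain carbon changes the half-maximal inhibitory concentration at all.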